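The source may report more compounds than this note shows. Statements on the series, on what has been measured and on what is new or still open speak of the compounds shown alone.

Measured so far in a functional assay on MCF7 cells (Homo sapiens) for antiproliferative activity, read by MTT assay, with a stated time of 72 h; on this read-out lower numbers stand for stronger inhibition and higher numbers for weaker inhibition:
- Compound 1 `CCCSc1nc(N/N=C/c2ccc(C)cc2)c2nnn(Cc3ccccc3)c2n1`: > 64000 nM, a limit
- Compound 2 `CCCSc1nc(N/N=C/c2cccc(Cl)c2)c2nnn(Cc3ccccc3)c2n1`: > 64000 nM, a limit

Compound 2 has no numerical value, only the limit > 64000 nM. Compound 1 likewise has only a limit, > 64000 nM. The record so far therefore comes down to one observation: the limit of > 64000 nM in this assay, at which 2 of the 2 values shown sit.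

Compound 3 `CCCSc1nc(N/N=C/c2cccs2)c2nnn(Cc3ccccc3)c2n1` carries thiophen-2-yl in place of 3-chlorophenyl on a carbon with a double bond to nitrogen.

For the measured compounds named here, only one measured step bears on this change, and it involves the same carbon: a step that the two limits leave unreadable from compound 1 to compound 2. That step has no readable size, so it gives no direction for the new change. Since compound 1 stays at > 64000 nM and compound 2 at > 64000 nM, compound 3 is also expected to stay near the limit in this assay, with no step beyond the scatter. The expected change is an at least 1.0-fold lower number from compound 2 to compound 3 (0.02 log units; that floor lies within the scatter). For compound 3 the estimated value is 60000 nM, with an expected range from 20000 nM to 100000 nM.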

Compound 3, half-maximal inhibitory concentration: > 64000 nM
Compound 3: a limit, no number; the forecaster's own chance of this, stated with the estimate: 75%; middle value at least 1.0-fold (0.02 log units) away from the limit.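

In this assay compound 3 gives > 64000 nM, a limit and not a number. No step can be read among compound 1, compound 2 and compound 3, because all three stop at the same limit: the limit of > 64000 nM in this assay, at which 3 of the 3 values shown sit.

The compounds shown leave open whether any group on the carbon with a double bond to nitrogen gives a readable number.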